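Two Changes on One Core: Estimating Compound 4

The source may hold more compounds than are shown below. What is called first, only, known or untested is meant among the compounds shown, and "the series" means these compounds.

Compound 1 `O=C(Nc1ccc(Oc2ccnc3[nH]ccc23)c(F)c1)c1cc2cccnc2n(-c2ccc(Br)cc2F)c1=O`: 820 nM
Compound 2 `O=C(Nc1ccc(Oc2ccnc3[nH]ccc23)c(F)c1)c1cc2cccnc2n(-c2ccc(C(F)(F)F)cc2Cl)c1=O`: 1360 nM
Compound 3 `Cn1ccc2c(Oc3ccc(NC(=O)c4cc5cccnc5n(-c5ccc(Br)cc5F)c4=O)cc3F)ccnc21`: 3290 nM

Of the compounds shown here, three built on one shared core have been measured in a functional assay on HT-29 cells (Homo sapiens) for antiproliferative activity, read by MTT assay, with a stated time of 72 h; on this read-out higher numbers stand for weaker inhibition and lower numbers for stronger inhibition. Two single changes to compound 1 have been tried. The first is 2-chloro-4-(trifluoromethyl)phenyl in place of 4-bromo-2-fluorophenyl on an aromatic nitrogen; it produced a 1.7-fold higher number from compound 1 to compound 2 (0.22 log units; within the scatter). The second is methyl in place of hydrogen on an aromatic nitrogen; it produced a 4.0-fold higher number from compound 1 to compound 3 (0.60 log units; beyond the scatter), and compound 3 therefore carries the highest number of the three.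

Compound 4 `Cn1ccc2c(Oc3ccc(NC(=O)c4cc5cccnc5n(-c5ccc(C(F)(F)F)cc5Cl)c4=O)cc3F)ccnc21` has not yet been measured in this assay. It carries both changes at once, and it differs from compound 3 in exactly one place: 2-chloro-4-(trifluoromethyl)phenyl in place of 4-bromo-2-fluorophenyl on an aromatic nitrogen. Among the compounds with values here, this is the same change as the one from compound 1 to compound 2, made at a place described in identical words, so the earlier step is the only guide available for it.

Within the data shown here, the expected step is a 1.5-fold higher number from compound 3 to compound 4 (0.18 log units; within the scatter), because a 1.7-fold higher number from compound 1 to compound 2 (0.22 log units; within the scatter) is the one example of this change here and it stayed within the scatter. Since compound 3 starts from 3290 nM, the estimate for compound 4 in this assay is 5000 nM, with a plausible range from 2200 nM to 12000 nM. The range is wide because the expectation rests on a single measured pair.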

Compound 4, half-maximal inhibitory concentration: 5830 nM
Compound 4: the middle estimate sits 1.2-fold (0.07 log units) below what was measured; the range from low to high includes it.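

In this assay, 2-chloro-4-(trifluoromethyl)phenyl in place of 4-bromo-2-fluorophenyl on an aromatic nitrogen gave a 1.8-fold higher number from compound 3 to compound 4 (0.25 log units; within the scatter), and this step agrees with the one seen earlier: the same change on two cores in this assay, a 1.7-fold higher number (0.22 log units; within the scatter) from compound 1 to compound 2 and a 1.8-fold higher number (0.25 log units; within the scatter) from compound 3 to compound 4, 1.1-fold (0.03 log units) apart, within the scatter of two such steps

Methyl in place of hydrogen on an aromatic nitrogen gave a 4.3-fold higher number from compound 2 to compound 4 (0.63 log units; beyond the scatter), and this step also agrees with its earlier counterpart: the same change on two cores in this assay, a 4.0-fold higher number (0.60 log units; beyond the scatter) from compound 1 to compound 3 and a 4.3-fold higher number (0.63 log units; beyond the scatter) from compound 2 to compound 4, 1.1-fold (0.03 log units) apart, within the scatter of two such steps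

Across these four compounds, then, each change carried over from one core to the other at much the same size, so the two changes behaved as if independent; however, each comparison rests on a single pair of steps, the step for the aromatic ring swap stays within the scatter on both cores and so does not show that this swap shifts the number at all, and nothing here explains why either step has its size.

The compounds shown leave open whether the same carry-over would hold for a larger group on that aromatic nitrogen, such as an ethyl group, a longer chain or a chain ending in an amine. They also leave open how a phenyl ring bearing a nitrile or a methoxy group would behave in place of the two aromatic groups seen here.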